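The source may report more compounds than this note shows. Statements on the series, on what has been measured and on what is new or still open speak of the compounds shown alone.

The series shares one core, in which a pyrazole-type ring fused to a saturated ring bearing an ethyl group on a basic nitrogen carries a carbonyl linked to an amide-type nitrogen, and the arylamide on that nitrogen varies. Compound 1 `CCN1CCc2c(c(C)nn2C(=O)Nc2ccc(Cl)cc2)C1` carries a methyl group on the core and a 4-chlorophenyl on the amide-type nitrogen; in a functional assay on the whole organism (strain Swiss albino) for inhibition, with Mus musculus as the target, in the writhing test, with a stated time of 30 min, at a dose of 100 mg/kg (a lower number here means less inhibition, a higher number more inhibition at the dose given (going by the name of the read-out)), compound 1 gives 55.2%. Compound 2 `CCN1CCc2c(c(C(C)(C)C)nn2C(=O)Nc2cc(C)ccc2C)C1` carries a tert-butyl group on the core and a 2,5-dimethylphenyl on the amide-type nitrogen; in this assay compound 2 gives 63.1%. Of the two numbers shown, the figure for compound 2 is not separated from that for compound 1 beyond the usual scatter, so the two stand together.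

Compound 3 `CCN1CCc2c(c(C(C)(C)C)nn2C(=O)Nc2ccc(Cl)cc2)C1` has not yet been measured in this assay. It differs from compound 2 in one place: 4-chlorophenyl in place of 2,5-dimethylphenyl on an amide-type nitrogen. Because compound 1 with the same 4-chlorophenyl gives 55.2%, and compound 2 with the tert-butyl group gives 63.1%, no step beyond the scatter is expected from this change, in either direction. The step from compound 2 to compound 3 is estimated as a number 4.1 percentage points lower from compound 2 to compound 3 (within the scatter). For compound 3 the expected value in this assay is 59%, with a range from 45% to 72%.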

Compound 3, a percentage reported as inhibition, in the whole organism at one dose (the size of the read-out at that dose, not a potency): 15.8%
Beside the measured number, compound 3's estimate is 43.2 percentage points above it; the measured number lies below the stated range.
By their numbers in this assay, from the lowest: compound 3; then compounds 1 and 2 (each within the scatter of the next).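

In this assay, with tert-butyl held on the core, 4-chlorophenyl in place of 2,5-dimethylphenyl on the amide-type nitrogen gives a number 47.3 percentage points lower from compound 2 to compound 3 (beyond the scatter) and so shows that the group at this place can decide the read-out, which the two earlier compounds could not show, as they differ in two places at once. With 4-chlorophenyl held on that nitrogen, tert-butyl in place of methyl on an aromatic carbon gives a number 39.4 percentage points lower from compound 1 to compound 3 (beyond the scatter) and so shows that the group on the core can decide it as well, at least for this pair. Nothing measured here accounts for either step.

What the compounds shown leave open is how 2,5-dimethylphenyl would read with methyl on the core, and so whether the low figure of compound 3 belongs to one of the two groups alone or only to the two together. They also leave open what this assay would show for an amine or a carboxylic acid in place of the aryl group on the amide-type nitrogen, or for a longer chain in place of tert-butyl on the core.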